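Diyne-linked nucleosides: aryl-to-cyclopentylmethyl swap at the terminus

This account rests on a few compounds, and the source may have more. Where it says the series, first, only, none or still open, it means among the compounds named here.

Measured compounds, values in an ADME assay on HEL cells (Homo sapiens), read by cell counting, with a stated time of 3 days; on this read-out lower numbers stand for higher toxicity in this test and higher numbers for lower toxicity in this test:
- compound 1 `O=c1[nH]c(=O)n([C@H]2C[C@H](O)[C@@H](CO)O2)cc1C#CC#Cc1ccccc1`: 100000 nM
- compound 2 `O=c1[nH]c(=O)n([C@H]2C[C@H](O)[C@@H](CO)O2)cc1C#CC#Cc1ccccn1`: 1500 nM
- compound 3 `Cc1cc(C#CC#Cc2cn([C@H]3C[C@H](O)[C@@H](CO)O3)c(=O)[nH]c2=O)ccc1F`: 45000 nM

Compound 3 stands second highest of the three numbers in this assay. Its nearest neighbour is compound 1, by the step of a 2.2-fold lower number from compound 1 to compound 3 (0.35 log units; beyond the scatter); its furthest is compound 2, by the step of a 30-fold higher number from compound 2 to compound 3 (1.48 log units; beyond the scatter). The one large move in the set is a 67-fold lower number from compound 1 to compound 2 (1.82 log units; beyond the scatter).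

Compound 4 `O=c1[nH]c(=O)n([C@H]2C[C@H](O)[C@@H](CO)O2)cc1C#CC#CCC1CCCC1` differs from compound 3 in one place: cyclopentylmethyl in place of 4-fluoro-3-methylphenyl on a triple-bonded carbon. Within the data shown here, none of the measured steps replaces an aromatic ring on the triple-bonded carbon with a non-aromatic one, so no step bears directly on this change. The two aryl-to-aryl steps from compound 1 are of opposite size: modest for a 2.2-fold lower number from compound 1 to compound 3 (0.35 log units; beyond the scatter), large for a 67-fold lower number from compound 1 to compound 2 (1.82 log units; beyond the scatter), which shows that the terminal group can matter a great deal in this assay, but gives no direction for a cyclopentylmethyl terminus. Compound 3 and compound 1 both sit at the high end, and the expectation is that compound 4 stays near that region, with a step no larger than a 1.3-fold higher number from compound 3 to compound 4 (0.12 log units; within the scatter) expected. For compound 4 the estimate in this assay is 60000 nM, within a range from 15000 nM to 200000 nM.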

Compound 4, half-maximal cytotoxic concentration: 89000 nM
Beside the measured number, compound 4's estimate is 1.5-fold (0.17 log units) below it; low and high end bracket the measured number.
By their numbers in this assay, from the lowest: compound 2; then compounds 3, 4 and 1 (each within the scatter of the next, the first and the last beyond it).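

In this assay, the terminus on the triple-bonded carbon need not be aromatic to stay in the high part of the range: cyclopentylmethyl replaces a six-membered aromatic ring of carbon only with no step beyond the scatter, either for 4-fluoro-3-methylphenyl (a 2.0-fold higher number from compound 3 to compound 4 (0.30 log units; within the scatter)) or for phenyl (a 1.1-fold lower number from compound 1 to compound 4 (0.05 log units; within the scatter)). Among these four compounds, the low number remains confined to the pyridin-2-yl terminus of compound 2, and the non-aromatic terminus gives the same separation from it as the other termini do in direction (a 59-fold higher number from compound 2 to compound 4 (1.77 log units; beyond the scatter)), so the change to cyclopentylmethyl reads as tolerated rather than as a new effect at this position. No measurement at hand offers a reason for either the flat steps or the gap to compound 2.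

Open, from the compounds shown here alone, is whether ring nitrogen itself carries the low number, which a pyridin-3-yl or pyridin-4-yl terminus would test, and whether a nitrogen in a non-aromatic terminus, such as a piperidine or an amine on the cyclopentyl ring, behaves like pyridin-2-yl or like cyclopentylmethyl. Also open, going by these compounds, is how an open-chain terminus, such as a longer alkyl chain, or a ring of another size, such as cyclohexylmethyl, would read in this assay.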